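This account rests on a few compounds, and the source may have more. Where it says the series, first, only, none or still open, it means among the compounds named here.

Measured in an ADME assay on the whole organism (Rattus norvegicus, strain Sprague-Dawley) for pharmacokinetics, using cassette dosing, at a dose of 1 mg/kg by the oral route; on this read-out higher numbers stand for higher oral bioavailability and lower numbers for lower oral bioavailability:
compound 1 `O=C(Nc1ccc2[nH]c(=O)oc2c1)C(=O)N1CCN(c2ccc(Cl)cc2)CC1`: 17.8%
compound 2 `O=C(Nc1ccc2[nH]c(=O)oc2c1)C(=O)N1CCN(c2ccc(Cl)c(F)c2)CC1`: 28.2%
compound 3 `O=C(Nc1ccc2[nH]c(=O)oc2c1)C(=O)N1CCN(c2ccc(C(F)(F)F)c(F)c2)CC1`: 8.7%

Compound 3, at 8.7%, cannot be told apart from compound 1 and sits clearly under compound 2. Compound 4 `COc1ccc(N2CCN(C(=O)C(=O)Nc3ccc4[nH]c(=O)oc4c3)CC2)cc1F` carries methoxy in place of trifluoromethyl on an aromatic carbon. Among the measured compounds shown here, no measured step involves methoxy. The closest guide is a number 19.5 percentage points lower from compound 2 to compound 3 (beyond the scatter), a modest step at the same aromatic carbon, while a number 10.4 percentage points higher from compound 1 to compound 2 (beyond the scatter) concerns the fluoro group that compound 3 and compound 4 share. A modest rise is therefore expected, with only part of that loss recovered. The estimated step is a number 9.3 percentage points higher from compound 3 to compound 4 (within the scatter), close to the scatter. For compound 4 the expected value is 18%, with an estimated range of 6% to 36%.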

Compound 4, oral bioavailability: 0.6%
Compound 4: middle estimate off by 17.4 percentage points, on the high side, and the stated range ends above it.
By their numbers in this assay, from the lowest: compounds 4, 3 and 1 (each within the scatter of the next, the first and the last beyond it); then compound 2.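

In this assay, the change at this position gives a number 8.1 percentage points lower from compound 3 to compound 4 (within the scatter), so methoxy and trifluoromethyl, on the aromatic carbon ortho to a fluoro group, cannot be told apart. Methoxy does not match chloro at this carbon, giving a number 27.6 percentage points lower from compound 2 to compound 4 (beyond the scatter). The 3-fluoro-4-methoxyphenyl group likewise falls short of 4-chlorophenyl, with a number 17.2 percentage points lower from compound 1 to compound 4 (beyond the scatter), so the gain seen with fluoro does not carry over to methoxy. From the compounds shown here alone, whether a methyl group, a nitrile or an amine at this carbon would match chloro remains open. Nothing measured here gives a reason for these results.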